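This account rests on a few compounds, and the source may have more. Where it says the series, first, only, none or still open, it means among the compounds named here.

Measured in a functional assay on DU-145 cells (Homo sapiens) for inhibition, read by MTT assay, with a stated time of 72 h; on this read-out higher numbers stand for weaker inhibition and lower numbers for stronger inhibition:
- compound 1 `O=C1C=C(N2CCN(c3ccc(Cl)cc3)CC2)C(=O)c2ccccc21`: 29500 nM
- compound 2 `O=C1C=C(N2CCN(c3ccc(Br)cc3)CC2)C(=O)c2ccccc21`: > 50000 nM, a limit of the assay and not a number
- compound 3 `Cc1ccc(N2CCN(C3=CC(=O)c4ccccc4C3=O)CC2)cc1`: 8200 nM

Compound 3 has the lowest number of the three, 8200 nM, which makes it the strongest inhibitor here. Methyl in place of chloro gives a 3.6-fold lower number from compound 1 to compound 3 (0.56 log units; beyond the scatter), and methyl in place of bromo gives an at least 6.0-fold lower number from compound 2 to compound 3 (0.78 log units; beyond the scatter).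

Compound 4 `O=C1C=C(N2CCN(c3ccccc3)CC2)C(=O)c2ccccc21` takes that methyl away again: hydrogen in place of methyl on an aromatic carbon. For the measured compounds named here, no measured step makes this exact change, so those two steps bear on it only indirectly. They show that the group at this place can move the number, and that methyl gave the lowest value of the groups tried. Hydrogen is untested, so a small rise in this assay seems the likeliest outcome, one that may stay within the scatter. The expected step is a 1.5-fold higher number from compound 3 to compound 4 (0.17 log units; within the scatter). For compound 4 the estimated value is 12000 nM, with an expected range of 4500 nM to 35000 nM.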

Compound 4, half-maximal inhibitory concentration: 9900 nM
Compound 4: the middle estimate sits 1.2-fold (0.08 log units) above what was measured; the measured number falls inside the stated range.
By their numbers in this assay, from the lowest: compounds 3 and 4 (each within the scatter of the next); then compound 1. At a limit, above all of these: compound 2.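

In this assay, hydrogen gives this position a plain reference point, and compound 3 and compound 4 cannot be told apart (a 1.2-fold higher number from compound 3 to compound 4 (0.08 log units; within the scatter)), so methyl shows no measurable gain over hydrogen. Replacing chloro with hydrogen lowers the number (a 3.0-fold lower number from compound 1 to compound 4 (0.47 log units; beyond the scatter)), and so does replacing bromo with hydrogen (an at least 5.0-fold lower number from compound 2 to compound 4 (0.70 log units; beyond the scatter)), which means the earlier gaps to methyl reflect higher numbers with chloro and bromo, not a gain from methyl. Compound 2 stands at a limit and not a number, so its step is only a floor (the value: the limit of > 50000 nM in this assay, at which 1 of the 4 values shown sits).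

From the compounds shown here alone, it remains open whether a group such as methoxy, an amine or a carboxylic acid at this place would lower the number further. A longer chain such as ethyl or butyl is equally untested among the compounds shown.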